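The source may report more compounds than this note shows. Statements on the series, on what has been measured and on what is new or still open speak of the compounds shown alone.

Measured compounds:
compound 1 `Oc1cccc(-c2cc(-c3cccc(Cl)c3)nc(-c3cccs3)c2)c1`, 2610 nM
compound 2 `Oc1ccc(-c2cc(-c3cccc(Cl)c3)nc(-c3cccs3)c2)cc1`, 5050 nM

Both were tested in a functional assay on HCT-15 cells (Homo sapiens) for cytotoxicity, read by CCK-8 assay and cell counting, with a stated time of 2 days; a higher number here means a weaker inhibitor, a lower number a stronger inhibitor. Of the two numbers, compound 1 has the lower, but the step of a 1.9-fold higher number from compound 1 to compound 2 (0.29 log units; within the scatter) lies within the scatter, so the two cannot really be told apart. Compound 3 `Oc1cccc(-c2cc(-c3cccs3)nc(-c3ccccc3Cl)c2)c1` has not yet been measured. It differs from compound 1 by 2-chlorophenyl in place of 3-chlorophenyl on an aromatic carbon; the changed group sits on an aromatic carbon of a six-membered aromatic ring with 1 nitrogen, next to the ring nitrogen. Among the measured compounds shown here, no measured step touches the chlorophenyl group: the only step, from compound 1 to compound 2, moves the hydroxyl on the other ring and stays within the scatter. There is therefore no basis for expecting a step beyond the scatter in this assay. Compound 3 is estimated at 3000 nM, between 1000 nM and 10000 nM. This estimate means a step of a 1.1-fold higher number from compound 1 to compound 3 (0.06 log units; within the scatter), expected to stay within the scatter.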

Compound 3, half-maximal inhibitory concentration: 2790 nM
Estimate against measurement, compound 3: 1.1-fold (0.03 log units) above, within the range that was stated.
By their numbers in this assay, from the lowest: compounds 1, 3 and 2 (each within the scatter of the next).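

In this assay, placing 2-chlorophenyl in place of 3-chlorophenyl gives a 1.1-fold higher number from compound 1 to compound 3 (0.03 log units; within the scatter), so the two arrangements of the chlorine cannot be told apart. Among the compounds shown here, this is the first view of the group next to the ring nitrogen, since the earlier step changed only the hydroxyl on the other ring, and it shows that this position allows the chlorine to sit at either of these two ring places without a change beyond the scatter. Nothing available explains this result.

Still open, as far as these compounds go, is whether the same holds for 4-chlorophenyl, or when the chlorine gives way to a different atom or group, such as fluorine, methoxy or an amine. A carboxylic acid on this ring would test a much larger departure from the chlorophenyl group.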